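Notes on compound 3 and compound 4

The source may report more compounds than this note shows. Statements on the series, on what has been measured and on what is new or still open speak of the compounds shown alone.

Of the compounds shown here, three sharing one core have been measured in an ADME assay on microsomes from liver (Homo sapiens) for metabolic stability; a lower number here means that the compound disappears faster, a higher number that the compound lasts longer: compound 1 `COc1nc2ccc(Br)cc2cc1[C@@H](c1cc(C)c(C)s1)[C@@](O)(CCN(C)C)c1cccc(F)c1` gives 1 h, compound 2 `COc1nc2ccc(Br)cc2cc1[C@@H](c1cncc(C)c1)[C@@](O)(CCN(C)C)c1cccc(F)c1` gives 0.2 h and compound 3 `COc1nc2ccc(Br)cc2cc1[C@@H](c1cccnc1N(C)C)[C@@](O)(CCN(C)C)c1cccc(F)c1` gives 0.25 h. Compound 3 thus shares the lower part of this small range with compound 2, while compound 1 stands apart. The two larger steps are a 5.0-fold lower number from compound 1 to compound 2 (0.70 log units; beyond the scatter) and a 4.0-fold lower number from compound 1 to compound 3 (0.60 log units; beyond the scatter). Both leave the 4,5-dimethylthiophen-2-yl group of compound 1, which plays no part in the next change.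

Compound 4 `COc1nc2ccc(Br)cc2cc1[C@@H](c1ccc(N(C)C)nc1)[C@@](O)(CCN(C)C)c1cccc(F)c1` has the same atoms as compound 3, joined differently: 6-(dimethylamino)pyridin-3-yl in place of 2-(dimethylamino)pyridin-3-yl on a saturated chain carbon bound to an aromatic carbon and a saturated chain carbon. Here 6-(dimethylamino)pyridin-3-yl takes the place of 2-(dimethylamino)pyridin-3-yl on a saturated chain carbon bound to an aromatic carbon and a saturated chain carbon.

For the measured compounds named here, no measured pair isolates this exact exchange, so the evidence is indirect. The nearest guide is the exchange of one pyridin-3-yl group for another, a 1.3-fold higher number from compound 2 to compound 3 (0.10 log units; within the scatter). On that basis, no step beyond the scatter is expected in this assay, and the expected step is no change at the digits printed from compound 3 to compound 4 (within the scatter). For compound 4 the estimated half-life is 0.25 h, with an expected range of 0.12 h to 0.55 h.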

Compound 4, half-life: 0.3 h
Estimate against measurement, compound 4: 1.2-fold (0.08 log units) below; low and high end bracket the measured number.
By their numbers in this assay, from the lowest: compounds 2, 3 and 4 (each within the scatter of the next); then compound 1.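

Exchanging 2-(dimethylamino)pyridin-3-yl for 6-(dimethylamino)pyridin-3-yl rearranges the same atoms at this position, and in this assay the result is only a 1.2-fold higher number from compound 3 to compound 4 (0.08 log units; within the scatter). The new group also stays close to the 5-methylpyridin-3-yl group, with a 1.5-fold higher number from compound 2 to compound 4 (0.18 log units; within the scatter), so compounds 2, 3 and 4 now form one group of three pyridin-3-yl compounds, none separated from another beyond the scatter. The 4,5-dimethylthiophen-2-yl group remains apart from this new member as well, with a 3.3-fold lower number from compound 1 to compound 4 (0.52 log units; beyond the scatter), and nothing available accounts for that separation or for the closeness of the three pyridin-3-yl compounds.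

The compounds shown leave open whether the longer half-life of compound 1 belongs to the thiophene ring itself or to its two methyl groups, a question that an unsubstituted thiophen-2-yl group at the same place would address. They also leave open whether a phenyl group carrying dimethylamino would stay with the pyridin-3-yl compounds or come closer to compound 1.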